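This account rests on a few compounds, and the source may have more. Where it says the series, first, only, none or still open, it means among the compounds named here.

Of the compounds shown here, three sharing one core have been measured in an ADME assay on HepG2 cells (Homo sapiens) for cytotoxicity, read by luminescence, CellTiter-Glo and ATP content, with a stated time of 72 h; on this read-out higher numbers stand for an effect only at larger amounts of compound and lower numbers for an effect already at smaller amounts. Compound 1 `COc1ccc(F)cc1CNCCCNc1ccnc2cc(Oc3ccc(C(C)(C)C)cc3)ccc12` gives 7200 nM, compound 2 `COc1ccc(F)cc1CNCCCNc1ccnc2cc(Cc3ccc(F)cc3Cl)ccc12` gives 2460 nM, and compound 3 `COc1ccc(F)cc1CNCCCNc1ccnc2cc(Cc3ccccc3)ccc12` gives 7990 nM. Where compound 3 stands is plain: its number and that of compound 1 lie within the scatter of each other, and a 3.2-fold higher number from compound 2 to compound 3 (0.51 log units; beyond the scatter) is the only step separating it from another compound beyond the scatter. Compound 4 `COc1ccc(-c2ccc3c(NCCCNCc4cc(F)ccc4OC)ccnc3c2)cc1` has not yet been measured; it differs from compound 3 in one place: 4-methoxyphenyl in place of benzyl on an aromatic carbon. For the measured compounds named here, two measured steps touch the same aromatic carbon. a 1.1-fold higher number from compound 1 to compound 3 (0.05 log units; within the scatter) and a 3.2-fold higher number from compound 2 to compound 3 (0.51 log units; beyond the scatter) show that exchanging the group there has moved the read-out only modestly, and no measured step replaces a benzyl with a 4-methoxyphenyl. For compound 4 a step of a 1.1-fold lower number from compound 3 to compound 4 (0.06 log units; within the scatter) is therefore expected, most likely not beyond the scatter. Compound 4 is estimated at 7000 nM, with a range from 3000 nM to 16000 nM.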

Compound 4, half-maximal effective concentration: 5960 nM
Beside the measured number, compound 4's estimate is 1.2-fold (0.07 log units) above it; the range from low to high includes it.
By their numbers in this assay, from the lowest: compound 2; then compounds 4, 1 and 3 (each within the scatter of the next).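

In this assay the 4-methoxyphenyl group on this aromatic carbon brings in a hydrogen-bond acceptor that benzyl lacks, yet the read-out stays within the scatter, with a 1.3-fold lower number from compound 3 to compound 4 (0.13 log units; within the scatter) as the step. The same holds against the larger 4-(tert-butyl)phenoxy group, with a 1.2-fold lower number from compound 1 to compound 4 (0.08 log units; within the scatter) as the step, so these three groups now form a set that this read-out does not separate. The 2-chloro-4-fluorobenzyl group remains the only one here that stands apart, and a 2.4-fold higher number from compound 2 to compound 4 (0.38 log units; beyond the scatter) shows this against a third group.

No supporting measurement explains these numbers. From the compounds shown here alone, whether a morpholine or a carboxylic acid on this aromatic carbon would shift the read-out remains open, as does whether the chlorine or the fluorine of the benzyl group accounts for the separation of compound 2.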